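Trifluoromethyl for fluoro on two cores of one series

The source may report more compounds than this note shows. Statements on the series, on what has been measured and on what is new or still open speak of the compounds shown alone.

Measured in a functional assay on A549 cells (Homo sapiens) for cytotoxicity, read by MTT assay, with a stated time of 72 h; a lower number here means a stronger inhibitor, a higher number a weaker inhibitor:
compound 1, `O=C(Nc1ccc(Oc2ccnc3[nH]ccc23)c(F)c1)c1nn(-c2ccc(Cl)c(F)c2)ccc1=O`, gives 10300 nM.
compound 2, `O=C(Nc1ccc(Oc2ccnc3[nH]ccc23)c(F)c1)c1nn(-c2ccc(Cl)c(C(F)(F)F)c2)ccc1=O`, gives 13400 nM.
compound 3, `Cn1ccc2c(Oc3ccc(NC(=O)c4nn(-c5ccc(Cl)c(F)c5)ccc4=O)cc3)ccnc21`, gives > 60000 nM, which is a limit of the assay and not a number.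

The change trifluoromethyl in place of fluoro on an aromatic carbon gives a 1.3-fold higher number from compound 1 to compound 2 (0.11 log units; within the scatter) in this assay. For compound 3 the reading sits at the limit of > 60000 nM in this assay, at which 1 of the 3 values shown sits, so only a limit is known. How the core of compound 1 differs from the core of compound 3 is not broken down here.

Compound 4, `Cn1ccc2c(Oc3ccc(NC(=O)c4nn(-c5ccc(Cl)c(C(F)(F)F)c5)ccc4=O)cc3)ccnc21`, carries the same change on the core of compound 3: trifluoromethyl in place of fluoro on an aromatic carbon. The place of the change reads the same word for word as in the step to compound 2, so it is the same change.

In this assay the step to compound 4 is expected to be a step that the limit leaves unreadable from compound 3 to compound 4, resting on the step of a 1.3-fold higher number from compound 1 to compound 2 (0.11 log units; within the scatter), which stayed within the scatter. Compound 4 is therefore expected at 80000 nM, between 35000 nM and 200000 nM, most likely reported again only as a limit.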

Compound 4, half-maximal inhibitory concentration: 11400 nM
Beside the measured number, compound 4's estimate is 7.0-fold (0.85 log units) above it; measured number below the stated range.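

Trifluoromethyl in place of fluoro on an aromatic carbon gives, in this assay, an at least 5.2-fold lower number from compound 3 to compound 4 (0.72 log units; beyond the scatter). This change therefore cannot be assumed to carry over from one core to the other in this series, as the two steps set side by side show: the same change on two cores in this assay, a 1.3-fold higher number (0.11 log units; within the scatter) from compound 1 to compound 2 and an at least 5.2-fold lower number (0.72 log units; beyond the scatter) from compound 3 to compound 4, at least 6.8-fold (0.83 log units) apart, beyond the scatter of two such steps What the pair does not show is which difference between the two cores lies behind this gap, or the full size of the step on the core of compound 3, which rests on a single limit of the assay: the limit of > 60000 nM in this assay, at which 1 of the 4 values shown sits.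

Going by these compounds alone, with only two cores and one pair of groups in hand, it remains open whether the gap would persist on any further core. As far as these compounds go, it is also open whether a nitrile or a methoxy group in place of the fluoro would follow the step to compound 2 or the step to compound 4.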